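The compounds below may be only part of what the source reports. "The series", "measured", "known", "first", "only" and "open" are said of these compounds alone.

Three compounds share one core and were all tested in a functional assay on MIA PaCa-2 cells (Homo sapiens) for antiproliferative activity, read by MTT assay, with a stated time of 3 days; a lower number here means a stronger inhibitor, a higher number a weaker inhibitor. Compound 1 `CCCCCCCCC#Cc1cn(C/C=C\CN2C(=O)c3ccccc3C2=O)c(=O)[nH]c1=O` gives 68000 nM in this assay. For compound 2 `CCCCCc1ccc(C#Cc2cn(C/C=C\CN3C(=O)c4ccccc4C3=O)c(=O)[nH]c2=O)cc1` this assay reports only a limit, > 100000 nM. For compound 3 `CCCCC#Cc1cn(C/C=C\CN2C(=O)c3ccccc3C2=O)c(=O)[nH]c1=O` this assay likewise reports only a limit, > 100000 nM. Compound 3 therefore stands at the edge of what this assay can read, a position it shares with one other value (the limit of > 100000 nM in this assay, at which 2 of the 3 values shown sit). Compound 4 `O=C1c2ccccc2C(=O)N1C/C=C\Cn1cc(C#CCCc2ccccc2)c(=O)[nH]c1=O` has not yet been measured. It differs from compound 3 in one place: phenyl in place of ethyl on a saturated chain carbon, two bonds along the chain from a triple-bonded carbon. Within the data shown here, two measured steps touch on this. The step of an at least 1.4-fold higher number from compound 1 to compound 3 (0.16 log units; that floor lies within the scatter) came from hydrogen in place of butyl on a saturated chain carbon, so it is the nearest guide to growing the chain, and its floor lies within the scatter. The step that the two limits leave unreadable from compound 2 to compound 3 cannot be sized. Neither gives a clear direction for a phenyl entering the chain. Compound 4 is therefore expected near 100000 nM, between 40000 nM and 300000 nM. This estimate means a step of a number no higher from compound 3 to compound 4 (the limit leaves the size open) that may well again end at a limit.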

Compound 4, half-maximal inhibitory concentration: > 100000 nM
Compound 4: a limit, no number; the forecaster's own chance of this, stated with the estimate: 60%; the middle value lies on the limit itself.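

In this assay, compound 4 gives only a limit, > 100000 nM. Among these compounds, the steps from compound 2 and compound 3 to this compound cannot be read, and the one readable step is an at least 1.4-fold higher number from compound 1 to compound 4 (0.16 log units; that floor lies within the scatter), so these values do not separate that pair. What this result adds is that the phenethyl of compound 4 ends at the same limit as the butyl of compound 3 and the 4-pentylphenyl of compound 2: the limit of > 100000 nM in this assay, at which 3 of the 4 values shown sit.

Among the compounds shown here, compound 1, with its octyl chain, is the only compound here with a number, so it remains open how activity changes along this series. Also open, from the compounds shown here alone, is what an amine or a carboxylic acid in place of this phenyl would give in this assay.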